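Adding furan-3-yl to the unsubstituted compound 3

This account rests on a few compounds, and the source may have more. Where it says the series, first, only, none or still open, it means among the compounds named here.

Compound 3 (`Nc1ncc(-c2ccncc2)cn1`) is the smallest member of this series in a functional assay on CUTLL1 cells (Homo sapiens) for inhibition, read by resazurin assay, with a stated time of 48 h, in the absence of a further agent; on this read-out lower numbers stand for an effect already at smaller amounts and higher numbers for an effect only at larger amounts of compound. Compound 3 reads > 100000 nM, which is a limit of the assay and not a number. Going by the values given here, this is the only such limit among the three values so far (the limit of > 100000 nM in this assay, at which 1 of the 3 values shown sits), so compound 3 gives no exact starting point for a step.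

Compound 4 (`Nc1ncc(-c2ccncc2)c(-c2ccoc2)n1`) differs from it by furan-3-yl in place of hydrogen on an aromatic carbon. The new group sits on the six-membered aromatic ring with 2 nitrogen, next to the ring nitrogen and ortho to the pyridin-4-yl group.

Among the compounds with values here, only one measured step bears on this change, and only indirectly. Compound 1 (`Nc1ncc(-c2ccncc2Br)c(C2CC2)n1`) gives 99000 nM and compound 2 (`Nc1ncc(-c2ccncc2-c2ccoc2)c(C2CC2)n1`) gives 28000 nM. That is a 3.5-fold lower number from compound 1 to compound 2 (0.55 log units; beyond the scatter), a modest gain on swapping a bromo group for furan-3-yl. There the furan-3-yl replaces bromo rather than hydrogen and sits at another place on the molecule, so the comparison is loose.

A modest move towards lower numbers is therefore expected, with the reading possibly remaining at the limit. The expected change is an at least 2.0-fold lower number from compound 3 to compound 4 (0.30 log units; that floor lies within the scatter). For compound 4 the estimated value is 50000 nM. The expected range for compound 4 runs from 15000 nM to 100000 nM.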

Compound 4, half-maximal effective concentration: > 100000 nM
Compound 4: only a limit was reported; the forecaster's own chance of this, stated with the estimate: 30%; at least 2.0-fold (0.30 log units) between middle value and limit.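

Compound 4, like compound 3, reads as a limit of the assay and not a number, so no step from compound 3 to compound 4 can be read: the limit of > 100000 nM in this assay, at which 2 of the 4 values shown sit.

The compounds shown leave open whether furan-3-yl in place of hydrogen on an aromatic carbon changes the reading at all in this assay for this pair.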